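The compounds below may be only part of what the source reports. "The series", "measured", "known", "first", "only" and "open" are said of these compounds alone.

In a functional assay on MCF7 cells (Homo sapiens) for antiproliferative activity, read by MTT assay (a lower number here means a stronger inhibitor, a higher number a weaker inhibitor), two compounds sharing one core have been measured so far. Compound 1 (`O=[N+]([O-])c1ccc(Nc2nccc(-c3ccc(Br)cc3)n2)cc1`), the bromo member, gives 681000 nM. Compound 2 (`O=[N+]([O-])c1ccc(Nc2nccc(-c3ccc(F)cc3)n2)cc1`), the fluoro member, gives 400 nM, the lower of the two numbers. Compound 3 (`O=[N+]([O-])c1ccc(Nc2nccc(-c3ccc(Cl)c(Cl)c3)n2)cc1`) keeps the shared core and carries 3,4-dichlorophenyl in place of 4-fluorophenyl on an aromatic carbon.

For the measured compounds named here, one measured step bears on this change: a 1700-fold lower number from compound 1 to compound 2 (3.23 log units; beyond the scatter), for fluoro in place of bromo on an aromatic carbon. That step is large and lies well beyond the scatter, so the halogen here can matter greatly in this assay. Going by the values given here, still, no chlorinated compound has been measured, and two compounds establish no trend. Compound 1, which lacks the fluoro, stands at 681000 nM, so losing the fluoro of compound 2 points towards a higher number, though probably not as far. The expected change is a sizeable weakening beyond the scatter, an estimated 38-fold higher number from compound 2 to compound 3 (1.57 log units; beyond the scatter). For compound 3 the expected value is 15000 nM, with an estimated range of 1000 nM to 200000 nM.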

Compound 3, half-maximal inhibitory concentration: 3510 nM
Compound 3: middle estimate off by 4.3-fold (0.63 log units), on the high side; low and high end bracket the measured number.
By their numbers in this assay, from the lowest: compound 2; then compound 3; then compound 1.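

In this assay, the step of an 8.8-fold higher number from compound 2 to compound 3 (0.94 log units; beyond the scatter) shows that this position tolerates a change from a single fluoro to two chloro substituents on the phenyl ring with only a modest loss, so the very high number of compound 1 is not shared by every halogenated member of this small set. The step of a 190-fold lower number from compound 1 to compound 3 (2.29 log units; beyond the scatter) places compound 3 much nearer to compound 2 than to compound 1, and it shows that the large gap first seen between the bromo and fluoro members can be largely closed by a different halogen pattern, with 3,4-dichlorophenyl in place of 4-bromophenyl. Nothing available accounts for these differences or explains why compound 1 stands so far apart.

On these data alone, with three compounds, it remains open whether the number of compound 3 depends on both chloro substituents or mainly on one of them. It is also unknown how this position would respond to a phenyl ring bearing a methoxy group or an amine instead of a halogen, or to an unsubstituted phenyl ring.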